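Replacing chloro with (3-fluorobenzyl)oxy at the assay limit

The source may hold more compounds than are shown below. What is called first, only, known or untested is meant among the compounds shown, and "the series" means these compounds.

Compound 1 `O=C(CCCCCC(=O)Nc1ccc(O)c(C(=O)Nc2ccc(F)c(Cl)c2)c1)NO`: > 100000 nM (a limit)
Compound 2 `O=C(CCCCCC(=O)Nc1ccc(O)c(C(=O)Nc2ccc(Cl)c(Cl)c2)c1)NO`: > 100000 nM (a limit)

In a functional assay on HL-60 cells (Homo sapiens) for antiproliferative activity, read by MTT assay, with a stated time of 48 h (on this read-out higher numbers stand for weaker inhibition and lower numbers for stronger inhibition), compound 2 gives > 100000 nM, which is a limit of the assay and not a number. The whole picture so far is the limit of > 100000 nM in this assay, at which 2 of the 2 values shown sit. Compound 3 `O=C(CCCCCC(=O)Nc1ccc(O)c(C(=O)Nc2ccc(OCc3cccc(F)c3)c(Cl)c2)c1)NO` differs from compound 2 in one place: (3-fluorobenzyl)oxy in place of chloro on an aromatic carbon. This puts (3-fluorobenzyl)oxy in place of chloro on an aromatic carbon, ortho to a chloro group and para to a large group. For the measured compounds named here, the only measured step that bears on it is a step that the two limits leave unreadable from compound 1 to compound 2, which swaps a single halogen and offers no size to carry over. In this assay the expected step is therefore a modest move toward stronger inhibition, and it is quite uncertain: an at least 2.5-fold lower number from compound 2 to compound 3 (0.39 log units; beyond the scatter). For compound 3 the estimate is 40000 nM, with an expected range of 8000 nM to 120000 nM.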

Compound 3, half-maximal inhibitory concentration: > 100000 nM
Compound 3: a limit, no number (the forecaster's own chance of this, stated with the estimate: 45%); at least 2.5-fold (0.39 log units) between middle value and limit.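

Compound 3 gives a limit of the assay and not a number, as compound 1 and compound 2 do, so no step among these compounds can be read: the limit of > 100000 nM in this assay, at which 3 of the 3 values shown sit. Going by these compounds, how strongly each of them inhibits in this assay stays open, and so does whether (3-fluorobenzyl)oxy in place of chloro changes that.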